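Aryl swap on the saturated ring carbon: compound 4

The compounds below may be only part of what the source reports. "The series", "measured", "known", "first", "only" and "open" are said of these compounds alone.

Measured so far in an assay on HEK293 cells for inhibition of neurogenic locus notch homolog protein 1 (Homo sapiens), read by a luciferase reporter and resazurin assay, with a stated time of 16 h; on this read-out lower numbers stand for stronger inhibition and higher numbers for weaker inhibition:
compound 1 `CC1=C(C(=O)OCC2CCN(C(=O)OC(C)(C)C)CC2)C(c2cccc(Br)c2)C2=C(CC(C)(C)CC2=O)N1`: 360 nM
compound 2 `CC1=C(C(=O)OCC2CCN(C(=O)OC(C)(C)C)CC2)C(c2cccc(C(F)(F)F)c2)C2=C(CC(C)(C)CC2=O)N1`: 760 nM
compound 3 `CC1=C(C(=O)OCC2CCN(C(=O)OC(C)(C)C)CC2)C(c2ccc3ccccc3n2)C2=C(CC(C)(C)CC2=O)N1`: 330 nM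

Compound 3 gives the lowest number of the three in this assay, but its gap to compound 1 is within the scatter, a 1.1-fold lower number from compound 1 to compound 3 (0.04 log units; within the scatter), so the two cannot be ordered. Only compound 2 sits clearly apart: a 2.3-fold lower number from compound 2 to compound 3 (0.36 log units; beyond the scatter), and within the phenyl pair a 2.1-fold higher number from compound 1 to compound 2 (0.32 log units; beyond the scatter).

Compound 4 `CC1=C(C(=O)OCC2CCN(C(=O)OC(C)(C)C)CC2)C(c2ccc(Br)cc2F)C2=C(CC(C)(C)CC2=O)N1` is not yet measured. Its change from compound 3 is 4-bromo-2-fluorophenyl in place of quinolin-2-yl on a saturated ring carbon.

Among the measured compounds shown here, no measured step covers a 4-bromo-2-fluorophenyl group. For the measured compounds named here, the nearest guide is the step from the quinolin-2-yl of compound 3 back to a bromophenyl, a 1.1-fold lower number from compound 1 to compound 3 (0.04 log units; within the scatter), which was within the scatter; the only aryl change that moved the number beyond the scatter was the trifluoromethyl case, a 2.1-fold higher number from compound 1 to compound 2 (0.32 log units; beyond the scatter). Going by the values given here, a bromophenyl that additionally carries a fluorine has no precedent here, so the expectation is a small step, most likely none beyond the scatter or a modest rise.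

Compound 4 is therefore expected to come out near 500 nM, with a range of 200 nM to 1500 nM, meaning an estimated step of a 1.5-fold higher number from compound 3 to compound 4 (0.18 log units; within the scatter).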

Compound 4, half-maximal inhibitory concentration: > 10000 nM
Compound 4: a limit, no number; the forecaster's own chance of this, stated with the estimate: 5%; middle value at least 20-fold (1.30 log units) from the limit.
By their numbers in this assay, from the lowest: compounds 3 and 1 (each within the scatter of the next); then compound 2. At a limit, above all of these: compound 4.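

In this assay, compound 4 stands at a limit of the assay and not at a number: the limit of > 10000 nM in this assay, at which 1 of the 4 values shown sits. The steps to it can be read only as minimum sizes, and all three are large: an at least 30-fold higher number from compound 3 to compound 4 (1.48 log units; beyond the scatter), an at least 27-fold higher number from compound 1 to compound 4 (1.44 log units; beyond the scatter), and an at least 13-fold higher number from compound 2 to compound 4 (1.11 log units; beyond the scatter). Among compounds 1, 2 and 3, aryl changes on this saturated ring carbon gave steps no larger than modest, so the series now shows that an aryl swap here can move the read-out much further and that a bromophenyl group does not by itself keep the number low, since compound 1 also carries one.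

Compared with the 3-bromophenyl of compound 1, the 4-bromo-2-fluorophenyl of compound 4 changes both the place of the bromine and the presence of a fluorine, so the compounds shown do not tell which of the two goes with the large step. From the compounds shown here alone, a 4-bromophenyl group, a 2-fluorophenyl group, or an aryl group carrying an amine or a carboxylic acid at this carbon would remain open questions for the series.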